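Iodo for Methoxy on a Shared Amide Series

A few compounds are considered here, and "the series" means these few. Any claim that something is new, unique, unknown or untested is made for them only; others in the source may bear on it.

Of the compounds shown here, three built on one shared core have been measured, and a fourth has not. Compound 1 `Cc1ccc(NC(=O)c2ccc(I)cc2OCCCCn2ccnc2)cc1Nc1nccc(-c2cccnc2)n1`, compound 2 `COc1cc(C(=O)Nc2ccc(C)c(Nc3nccc(-c4cccnc4)n3)c2)ccc1OCCCCn1ccnc1` and compound 3 `COc1ccc(C(=O)Nc2ccc(C)c(Nc3nccc(-c4cccnc4)n3)c2)c(OCCCCn2ccnc2)c1` carry a 4-(1H-imidazol-1-yl)butoxy group on the amide-side ring and differ in what else that ring bears and where. In a functional assay on K562 cells (Homo sapiens) for cytotoxicity, read by XTT assay, with a stated time of 24 h (on this read-out higher numbers stand for weaker inhibition and lower numbers for stronger inhibition), compound 1 gives 57400 nM. In this assay compound 2 gives 29500 nM, and compound 3 gives 58900 nM. The value of compound 2 lies within the scatter of the other two, so the three cannot be ranked.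

Compound 3 and compound 1 differ in one place: iodo in place of methoxy on an aromatic carbon. That change gave a 1.0-fold lower number from compound 3 to compound 1 (0.01 log units; within the scatter). Compound 2 and compound 3 contain the same atoms joined differently; the difference between the two cores is not broken down here.

Compound 4 `Cc1ccc(NC(=O)c2ccc(OCCCCn3ccnc3)c(I)c2)cc1Nc1nccc(-c2cccnc2)n1` is the unmeasured member. It differs from compound 2 in one place: iodo in place of methoxy on an aromatic carbon. This is the same kind of change as that from compound 3 to compound 1, not the same: there the iodo sits meta to the 4-(1H-imidazol-1-yl)butoxy group and para to a large group, whereas in compound 4 it sits ortho to the 4-(1H-imidazol-1-yl)butoxy group and meta to a large group.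

In this assay the expected step is a 1.0-fold higher number from compound 2 to compound 4 (0.01 log units; within the scatter), resting on the earlier 1.0-fold lower number from compound 3 to compound 1 (0.01 log units; within the scatter), which stayed within the scatter. Compound 4 is therefore estimated at 30000 nM, with a range from 12000 nM to 75000 nM.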

Compound 4, half-maximal inhibitory concentration: 32500 nM
Beside the measured number, compound 4's estimate is 1.1-fold (0.03 log units) below it, within the range that was stated.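

In this assay, putting iodo in place of methoxy on the core of compound 2 gave a 1.1-fold higher number from compound 2 to compound 4 (0.04 log units; within the scatter), so on this second core too the step stays inside what repeated measurements would scatter by. Set beside the earlier case, the two steps agree: the same change on two cores in this assay, a 1.0-fold lower number (0.01 log units; within the scatter) from compound 3 to compound 1 and a 1.1-fold higher number (0.04 log units; within the scatter) from compound 2 to compound 4, 1.1-fold (0.05 log units) apart, within the scatter of two such steps. This shows that, in these two pairs, the swap of methoxy for iodo carried from one core to the other without a readable difference in this assay, even though the iodo stands ortho to a 4-(1H-imidazol-1-yl)butoxy group only on the second core; it does not show that the swap would leave the number unmoved on any further core or in another assay, and two steps that both stay within the scatter say nothing about how a step of readable size would carry.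

The compounds shown leave open whether another group at this place, such as a chloro, a trifluoromethyl or an amine, would give a step beyond the scatter. They also leave open what a shorter or longer chain in place of the butoxy link, or a carboxylic acid in place of the imidazole, would do to the number in this assay.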